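Pyridin-4-yl in place of its carbonyl on a hydrazine nitrogen

This account rests on a few compounds, and the source may have more. Where it says the series, first, only, none or still open, it means among the compounds named here.

Compound 1 `CC1(C)CC(=O)C2=C(C1)N(c1ccccc1)N=C(c1ccccc1)C2` gives 26% in a functional assay on the whole organism (strain CF) for inhibition, with Mus musculus as the target, at a dose of 25 mg/kg by the oral route; on this read-out lower numbers stand for less inhibition and higher numbers for more inhibition at the one dose given (going by the name of the read-out).
Compound 2 `CC1(C)CC(=O)C(CC(=O)c2ccccc2)=C(NNC(=O)c2ccncc2)C1` gives 51% in this assay.
Compound 3 `CCN(CC)CCn1nc(C)c(=O)c2c1CC(C)(C)CC2=O` gives 51% in this assay.

Compound 2 stands level with compound 3 at the digits given, the two together the highest of the three numbers, and their gap lies within the scatter. Compound 1 lies well below compound 2, beyond the scatter.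

Compound 4 `CC1(C)CC(=O)C(CC(=O)c2ccccc2)=C(NNc2ccncc2)C1` differs from compound 2 in one place: pyridin-4-yl in place of (pyridin-4-yl)carbonyl on an amine nitrogen. For the measured compounds named here, no measured pair shows this change. Compound 4 is therefore expected to sit near compound 2, with a step from compound 2 of a number 7 percentage points lower from compound 2 to compound 4 (within the scatter) in this assay that is not expected to exceed the scatter by much. In this assay compound 4 is estimated at 44%, between 22% and 66%.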

Compound 4, a percentage reported as inhibition, in the whole organism at one dose (the size of the read-out at that dose, not a potency): 76%
For compound 4 the middle estimate is 32 percentage points below the measured one; the measured number lies above the stated range.
By their numbers in this assay, from the lowest: compound 1; then compounds 2 and 3 (each within the scatter of the next); then compound 4.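

With the carbonyl gone and pyridin-4-yl sitting directly on the amine nitrogen, this assay gives a number 25 percentage points higher from compound 2 to compound 4 (beyond the scatter), so this read-out at the one dose does not depend on that carbonyl. The earlier compounds shown here included no pair differing in one place, and so could not show that this position affects the read-out at all. Nothing available explains why the step runs upward.

On these data alone, whether a phenyl group or an acetyl group on that amine nitrogen would reach the same level stays open. So does whether the step holds at other doses.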